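From 3,5-dichlorophenyl to 4-methoxyphenyl on an amine nitrogen

The compounds below may be only part of what the source reports. "The series", "measured", "known", "first", "only" and "open" are said of these compounds alone.

Compound 1 `C=C(c1cccc2ccccc12)C1CCC2(CC1)COC(Nc1ccc(OC)cc1)OO2` with 5.46
Compound 2 `C=C(c1ccc2ccccc2c1)C1CCC2(CC1)COC(Nc1cc(Cl)cc(Cl)c1)OO2` with 6.71

In a physicochemical assay for lipophilicity (a higher number here means a more lipophilic compound, a lower number a more polar compound), compound 2 stands highest of the two at 6.71 and lies beyond the scatter from compound 1. Compound 3 `C=C(c1ccc2ccccc2c1)C1CCC2(CC1)COC(Nc1ccc(OC)cc1)OO2` is still unmeasured and has 4-methoxyphenyl in place of 3,5-dichlorophenyl on an amine nitrogen. Among the measured compounds shown here, no measured step shows this change directly. Compound 1 also bears 4-methoxyphenyl and gives 5.46 in this assay so a fall beyond the scatter is expected. The expected fall is sizeable (a number 1.21 log units lower from compound 2 to compound 3 (beyond the scatter)). Compound 3 is therefore estimated at 5.5 (expected range 5.1 to 5.9).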

Compound 3, partition coefficient: 5.46
Beside the measured number, compound 3's estimate is 0.04 log units above it, and the stated range covers the measured number.
By their numbers in this assay, from the lowest: compounds 1 and 3 (each within the scatter of the next); then compound 2.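

In this assay the change on the amine nitrogen now has a direct reading: 4-methoxyphenyl in place of 3,5-dichlorophenyl gives a number 1.25 log units lower from compound 2 to compound 3 (beyond the scatter) as a large step. Naphthalen-2-yl in place of naphthalen-1-yl on the double-bonded chain carbon gives no change at the digits printed from compound 1 to compound 3 (within the scatter) in the same assay, so the two compounds bearing 4-methoxyphenyl read alike. No evidence is available that accounts for either step. On these data alone, what remains open is how a single chlorine, a trifluoromethyl or an unsubstituted phenyl on that nitrogen would read.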